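Chloro in place of methyl on the pendant phenyl

The compounds below may be only part of what the source reports. "The series", "measured", "known", "first", "only" and "open" are said of these compounds alone.

Among the measured compounds shown here, compound 2 `Cc1ccccc1-c1nc2c(NC3CCCC3)ncnc2n1C` gives 3000 nM in an assay on CHO cells for displacement of a labelled ligand from adenosine receptor A3 (Homo sapiens), read by scintillation counting, with a stated time of 3 h (on this read-out higher numbers stand for weaker inhibition and lower numbers for stronger inhibition), the highest of the three numbers measured so far. Compound 1 `CCn1c(-c2ccccc2)nc2c(NC3CCCCC3)ncnc21` gives 707 nM in this assay, and compound 3 `CCCn1c(-c2ccccc2)nc2c(NC3CCCCC3)ncnc21` gives 2360 nM; compound 2 and compound 3 lie within the scatter of each other, while the gap from compound 2 to compound 1 is beyond the scatter. For the measured compounds named here, the only single-point step measured, a 3.3-fold higher number from compound 1 to compound 3 (0.52 log units; beyond the scatter), concerns a saturated chain carbon and does not touch the pendant ring. Compound 4 `Cn1c(-c2ccccc2Cl)nc2c(NC3CCCC3)ncnc21` differs from compound 2 by chloro in place of methyl on an aromatic carbon. Going by the values given here, no measured step probes this position, so in this assay the step of no change at the digits printed from compound 2 to compound 4 (within the scatter) is expected to stay within the scatter. Compound 4 is estimated at 3000 nM, ranging from 1000 nM to 9000 nM.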

Compound 4, inhibition constant: 720 nM
Compound 4: middle estimate off by 4.2-fold (0.62 log units), on the high side, outside the stated range (below it).
By their numbers in this assay, from the lowest: compounds 1 and 4 (each within the scatter of the next); then compounds 3 and 2 (each within the scatter of the next).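

In this assay the pendant phenyl is sensitive to its substituent: 2-methylphenyl to 2-chlorophenyl gives a 4.2-fold lower number from compound 2 to compound 4 (0.62 log units; beyond the scatter) and so is a step beyond the scatter. Among the compounds shown here, this is the only measured change on this ring, and it shows that the group on this aromatic carbon, ortho to a large group, can move the number. No measured evidence explains the step.

As far as these compounds go, it remains open how bromo, methoxy or plain hydrogen at this place would compare. From the compounds shown here alone, whether the same change carries over to the cyclohexyl-bearing compounds is also open.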